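Amine head swaps on a flavone side chain

A few compounds are considered here, and "the series" means these few. Any claim that something is new, unique, unknown or untested is made for them only; others in the source may bear on it.

Measured in a functional assay on BCG823 cells (Homo sapiens) for antiproliferative activity, read by MTT assay, with a stated time of 48 h; a higher number here means a weaker inhibitor, a lower number a stronger inhibitor:
- compound 1, `CN1CCN(CCCCOc2c(O)cc3oc(-c4ccccc4)cc(=O)c3c2O)CC1`: 82900 nM
- compound 2, `O=c1cc(-c2ccccc2)oc2cc(O)c(OCCCCN3CCCC3)c(O)c12`: 86400 nM
- compound 3, `COc1cc2oc(-c3ccccc3)cc(=O)c2c(O)c1OCCCN1CCCC1`: 6500 nM

Compound 2 and compound 1 share a core and differ only in the amine at the end of the chain: 4-methylpiperazin-1-yl in place of pyrrolidin-1-yl on a saturated chain carbon, four bonds along the chain from an oxygen on an aromatic ring. This step reads a 1.0-fold lower number from compound 2 to compound 1 (0.02 log units; within the scatter), so the two amines give indistinguishable numbers on that core.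

Compound 3 has the same atoms as compound 2 joined differently; the difference between the two cores is not broken down here. Compound 3 gives the lowest number of the three in this assay, and its gaps to compound 1 and compound 2 lie beyond the usual scatter.

Compound 4, `COc1cc2oc(-c3ccccc3)cc(=O)c2c(O)c1OCCCN1CCN(C)CC1`, is not yet measured. It relates to compound 3 as compound 1 relates to compound 2: 4-methylpiperazin-1-yl in place of pyrrolidin-1-yl on a saturated chain carbon, three bonds along the chain from an oxygen on an aromatic ring. The place is not identical, since in compound 3 the amine sits three bonds along the chain from the ring oxygen, whereas in compound 2 it sits four bonds along, so this is the same kind of change rather than the same change.

The expectation for compound 4 rests on compound 2 and compound 1, because a 1.0-fold lower number from compound 2 to compound 1 (0.02 log units; within the scatter) shows the amine swap left the number essentially unchanged on the one core where it was tested. The step from compound 3 is therefore expected to be small, a 1.1-fold higher number from compound 3 to compound 4 (0.03 log units; within the scatter). Compound 4 is estimated at 7000 nM, with a range of 3000 nM to 16000 nM, the width reflecting that the chain length and core differ from the measured pair.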

Compound 4, half-maximal inhibitory concentration: 31300 nM
Compound 4: the middle estimate sits 4.5-fold (0.65 log units) below what was measured; the measured number lies above the stated range.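

In this assay the swap of pyrrolidin-1-yl for 4-methylpiperazin-1-yl on the propyl chain gives a clear loss, with a 4.8-fold higher number from compound 3 to compound 4 (0.68 log units; beyond the scatter) as the step, so the near-silent result on the core of compound 2 does not carry over to the core of compound 3. Set side by side, the same change does not have one size in this series: the same change on two cores in this assay, a 1.0-fold lower number (0.02 log units; within the scatter) from compound 2 to compound 1 and a 4.8-fold higher number (0.68 log units; beyond the scatter) from compound 3 to compound 4, 5.0-fold (0.70 log units) apart, beyond the scatter of two such steps. Among the compounds shown here, this shows that the step depends on its surroundings, but it does not show which feature of the surroundings matters, since the two pairs differ both in the chain, with the amine three bonds along from the ring oxygen in one pair and four in the other, and in the rest of the core, and only one pair stands on each.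

The compounds shown leave open whether chain length or the rest of the core sets the size of the step, a question that a 3-(4-methylpiperazin-1-yl)propyl chain and its pyrrolidin-1-yl partner on the core of compound 2 could separate. Also open, as far as these compounds go, is how other amine heads, such as morpholine or piperidine, would read on the propyl chain of compound 3.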